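Chloro in Place of Methoxy on the Core of Compound 3

The source may hold more compounds than are shown below. What is called first, only, known or untested is meant among the compounds shown, and "the series" means these compounds.

Three compounds have so far been measured in an ADME assay on Vero cells (Chlorocebus sabaeus) for cytotoxicity, read by CCK-8 assay, with a stated time of 72 h; on this read-out higher numbers stand for weaker inhibition and lower numbers for stronger inhibition:

Compound 1, `Cc1ccn2nc(C)c(C(=O)NCc3ccc(N(C)C)cc3)c2c1`, gives > 100000 nM.
Compound 2, `Cc1ccc2c(C(=O)NCc3ccc(N4CCC(c5ccc(OC(F)(F)F)cc5)CC4)cc3)c(C)nn2c1`, gives > 100000 nM.
Compound 3, `COc1ccn2nc(C)c(C(=O)NCc3ccc(N4CCC(c5ccc(OC(F)(F)F)cc5)CC4)cc3)c2c1`, gives > 100000 nM.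

Each of these values is a limit of this assay and not a number. Compound 3 therefore stands at that limit, and the same holds for compound 1 and compound 2. Among the compounds with values here, the only measured step that touches compound 3 is a step that the two limits leave unreadable from compound 2 to compound 3, a step between two limits that cannot be read in either direction. Behind this stands (the limit of > 100000 nM in this assay, at which 3 of the 3 values shown sit), so there is no readable movement anywhere among the measured compounds.

Compound 4, `Cc1nn2ccc(Cl)cc2c1C(=O)NCc1ccc(N2CCC(c3ccc(OC(F)(F)F)cc3)CC2)cc1`, differs from compound 3 by chloro in place of methoxy on an aromatic carbon. Within the data shown here, the one measured step that bears on this, from compound 2 to compound 3, was unreadable, so no size or direction can be taken from it. Compound 4 is expected to sit at the limit of this assay as well, with an estimated value of 150000 nM and a range from 60000 nM to 400000 nM. The estimated step is a step that the limit leaves unreadable from compound 3 to compound 4, within the scatter.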

Compound 4, half-maximal inhibitory concentration: > 100000 nM
Compound 4: no number, only a limit (the forecaster's own chance of this, stated with the estimate: 85%); the middle value does not contradict the limit.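

In this assay compound 4 gives > 100000 nM as a limit and not a number. No new step can be read, neither from compound 3 to compound 4 nor from compound 2 to compound 4, and all values rest at one limit: the limit of > 100000 nM in this assay, at which 4 of the 4 values shown sit.

The compounds shown leave open whether chloro and methoxy on the core differ at all in this read-out.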